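The compounds below may be only part of what the source reports. "The series", "measured", "known", "first", "only" and "open" are said of these compounds alone.

Measured compounds in a functional assay on MCF7 cells (Homo sapiens) for cytotoxicity, read by sulforhodamine B assay; on this read-out higher numbers stand for weaker inhibition and lower numbers for stronger inhibition:
Compound 1 `C=C1[C@@H](C/C=C2/C(=O)OC[C@H]2OC(C)=O)[C@]2(C)CC[C@@H](OC(C)=O)[C@@](C)(CO[Si](C)(C)C(C)(C)C)[C@H]2C[C@@H]1O` gives 6960 nM.
Compound 2 `C=C1[C@@H](OC(C)=O)C[C@@H]2[C@](C)(CO[Si](C)(C)C(C)(C)C)[C@H](OC(C)=O)CC[C@@]2(C)[C@@H]1C[C@@H](Nc1ccc(OC)cc1)C1=CCOC1=O` gives 4280 nM.
Compound 3 `C=C1[C@@H](OC(C)=O)C[C@@H]2[C@](C)(COC=O)[C@H](OC(C)=O)CC[C@@]2(C)[C@@H]1C[C@@H](Nc1ccc(OC)cc1)C1=CCOC1=O` gives 24200 nM.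

Compound 2 has the lowest of the three numbers in this assay; compound 1 sits within the scatter of it, while compound 3 lies further off, through a 5.7-fold higher number from compound 2 to compound 3 (0.75 log units; beyond the scatter). Compound 4 `C=C1[C@@H](OC(C)=O)C[C@@H]2[C@](C)(CO[Si](C)(C)C(C)(C)C)[C@H](OC(C)=O)CC[C@@]2(C)[C@@H]1C[C@@H](Nc1ccc(F)cc1)C1=CCOC1=O` differs from compound 2 by fluoro in place of methoxy on an aromatic carbon. Among the measured compounds shown here, no measured step touches the aromatic ring that carries this change; the one measured step, a 5.7-fold higher number from compound 2 to compound 3 (0.75 log units; beyond the scatter), concerns a group on an oxygen on a saturated carbon in a different part of the shared core and so gives no guide to the present change. Without a direct guide, the expected step is a 1.2-fold higher number from compound 2 to compound 4 (0.07 log units; within the scatter), not beyond the scatter. Compound 4 is therefore estimated at 5000 nM, with a range from 2000 nM to 12500 nM.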

Compound 4, half-maximal inhibitory concentration: 4340 nM
Compound 4: the middle estimate sits 1.2-fold (0.06 log units) above what was measured; low and high end bracket the measured number.
By their numbers in this assay, from the lowest: compounds 2, 4 and 1 (each within the scatter of the next); then compound 3.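

Earlier compounds varied other parts of the molecule, leaving this aromatic ring untested. In this assay, fluoro in place of methoxy gives a 1.0-fold higher number from compound 2 to compound 4 (0.01 log units; within the scatter) and so stays within the usual scatter. At this place on the ring, para to a large group, the two groups cannot be told apart, even though they differ in size and in hydrogen-bond acceptor count.

From the compounds shown here alone, whether an amine, a carboxylic acid or a longer alkoxy chain at this carbon would read the same remains open. No supporting measurement is available to explain why methoxy and fluoro read alike.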